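Anilino substituent series: fluoro to chloro on the shared core

The source may hold more compounds than are shown below. What is called first, only, known or untested is meant among the compounds shown, and "the series" means these compounds.

compound 1 `CCOc1ccc(NC2=CC(=O)c3ncncc3C2=O)cc1`: 0.02 ug/mL in a functional assay on SK-OV-3 cells (Homo sapiens) for cytotoxicity, read by MTT assay, with a stated time of 72 h; a lower number here means a stronger inhibitor, a higher number a weaker inhibitor
compound 2 `O=C1C(Nc2ccc(Br)cc2)=CC(=O)c2ncncc21`: 0.02 ug/mL in this assay
compound 3 `O=C1C(Nc2ccc(F)cc2)=CC(=O)c2ncncc21`: 0.07 ug/mL in this assay

Compound 3 stands highest of the three numbers in this assay; compounds 1 and 2 lie together, and a 3.5-fold higher number from compound 1 to compound 3 (0.54 log units; beyond the scatter) while a 3.5-fold higher number from compound 2 to compound 3 (0.54 log units; beyond the scatter). Compound 4 `O=C1C(Nc2ccc(Cl)cc2)=CC(=O)c2ncncc21` differs from compound 3 by chloro in place of fluoro on an aromatic carbon. For the measured compounds named here, the step that bears on this is the one between compound 2 and compound 3, where a 3.5-fold higher number from compound 2 to compound 3 (0.54 log units; beyond the scatter) went with fluoro in place of bromo; the present change is of the same kind in the opposite direction. A lower number for compound 4 in this assay is therefore expected, of modest size, a 2.3-fold lower number from compound 3 to compound 4 (0.37 log units; beyond the scatter). Compound 4 is estimated at 0.03 ug/mL, with a range from 0.015 ug/mL to 0.07 ug/mL.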

Compound 4, half-maximal inhibitory concentration: 0.01 ug/mL
Beside the measured number, compound 4's estimate is 3.0-fold (0.48 log units) above it, and the stated range ends above it.
By their numbers in this assay, from the lowest: compounds 4, 1 and 2 (each within the scatter of the next); then compound 3.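

In this assay there is a 7.0-fold lower number from compound 3 to compound 4 (0.85 log units; beyond the scatter) and this sets fluoro apart at this position, while a 2.0-fold lower number from compound 2 to compound 4 (0.30 log units; within the scatter) and a 2.0-fold lower number from compound 1 to compound 4 (0.30 log units; within the scatter) leave chloro level with bromo and ethoxy. Among the four compounds, only compound 3 stands separate from the others, so the para substituent matters here only in the case of fluoro. Nothing on hand accounts for the fluoro result.

On these data alone, whether an amine, a carboxylic acid or a longer chain at this position would stay with chloro, bromo and ethoxy or move with fluoro remains open. As far as these compounds go, whether the same order holds in other cell lines also remains open.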